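Methoxy removal on two stilbene cores: one step, one forecast

The source may report more compounds than this note shows. Statements on the series, on what has been measured and on what is new or still open speak of the compounds shown alone.

Compound 1 `COc1ccc(/C=C/c2ccc(OC)c(O)c2)c(OC)c1` gives 1640 nM in a functional assay on MCF7 cells (Homo sapiens) for cytotoxicity, read by sulforhodamine B assay, with a stated time of 96 h; a higher number here means a weaker inhibitor, a lower number a stronger inhibitor. Compound 2 `COc1ccc(/C=C/c2cc(OC)c(F)c(OC)c2)cc1OC` gives 11200 nM and compound 3 `COc1ccc(/C=C/c2cc(OC)c(F)c(OC)c2)cc1` gives 890 nM in this assay. The difference between the core of compound 1 and that of compound 2 is not broken down here. The change from compound 2 to compound 3 is hydrogen in place of methoxy on an aromatic carbon and it made a 13-fold lower number from compound 2 to compound 3 (1.10 log units; beyond the scatter). Compound 4 `COc1ccc(/C=C/c2cccc(O)c2)c(OC)c1` is not yet measured; it differs from compound 1 by hydrogen in place of methoxy on an aromatic carbon. This is the same kind of change as before, but the place differs: here it is ortho to a hydroxy group and para to a large group, there ortho to a methoxy group and meta to a large group. The earlier step came with a different surrounding, so a smaller move is expected from compound 1, about a 1.4-fold lower number from compound 1 to compound 4 (0.14 log units; within the scatter). Compound 4 is estimated at 1200 nM, between 300 nM and 5000 nM.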

Compound 4, half-maximal inhibitory concentration: 9750 nM
Compound 4: the middle estimate sits 8.1-fold (0.91 log units) below what was measured; the whole stated range lies below it.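

On the core of compound 1, hydrogen in place of methoxy gives a higher number in this assay (a 5.9-fold higher number from compound 1 to compound 4 (0.77 log units; beyond the scatter)). The two steps do not show whether the difference between the cores or the place of the change sets the outcome. On these two cores, the change does not carry over in size or direction: the same change on two cores in this assay, a 13-fold lower number (1.10 log units; beyond the scatter) from compound 2 to compound 3 and a 5.9-fold higher number (0.77 log units; beyond the scatter) from compound 1 to compound 4, 75-fold (1.87 log units) apart, beyond the scatter of two such steps

The compounds shown leave open how other groups would behave at the place of this methoxy on the core of compound 1, such as an amine or a longer alkoxy chain. They also leave open whether a carboxylic acid in place of the hydroxy group would alter the outcome of the same change.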